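Swapping methyl for phenyl in a cytotoxic pair

A few compounds are considered here, and "the series" means these few. Any claim that something is new, unique, unknown or untested is made for them only; others in the source may bear on it.

Compound 1 `C=C1C(=O)OCC1c1ccccc1`: in a functional assay on MIA PaCa-2 cells (Homo sapiens) for cytotoxicity, read by MTT assay, with a stated time of 72 h, tested at 10 uM (a higher number here means a weaker effect of the compound at the concentration tested, a lower number a stronger effect), compound 1 gives 14%.
Compound 2 `C=C1C(=O)O[C@H](c2ccc3ccccc3c2)[C@H]1C`: in this assay compound 2 gives 4%.

Both numbers are small, and they lie within the usual scatter of each other, so compound 2 cannot be called stronger than compound 1; both appear to act strongly at the tested concentration. Compound 3 `C=C1C(=O)O[C@H](c2ccc3ccccc3c2)[C@H]1c1ccccc1` has not yet been measured. It differs from compound 2 in one place: phenyl in place of methyl on a saturated ring carbon. Within the data shown here, no measured step of this kind exists to lean on, so the step expected in this assay is a number 4 percentage points higher from compound 2 to compound 3 (within the scatter), nothing beyond the scatter. Compound 3 is therefore estimated at 8%, between 2% and 25%.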

Compound 3, a percentage reported as activity, at one concentration (the size of the read-out at that concentration, not a potency): 3%
For compound 3 the middle estimate is 5 percentage points above the measured one; the measured number falls inside the stated range.
By their numbers in this assay, from the lowest: compounds 3, 2 and 1 (each within the scatter of the next, the first and the last beyond it).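

Phenyl in place of methyl on a saturated ring carbon, next to the ring atom that bears a large group, gives a number 1 percentage points lower from compound 2 to compound 3 (within the scatter) in this assay and so leaves the read-out essentially unchanged. This position therefore accepts an aromatic ring without losing the strong effect at the tested concentration. Among these compounds, at this single concentration, however, the result gives no potency for either compound. On these data alone, whether an amine or a carboxylic acid on this carbon would keep the effect remains open. No measurement shown accounts for this result.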